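Swapping a Methoxy for a Nitro on a Shared Core

The source may hold more compounds than are shown below. What is called first, only, known or untested is meant among the compounds shown, and "the series" means these compounds.

Of the compounds shown here, two built on a shared core have been measured. In a functional assay on MCF7 cells (Homo sapiens) for cytotoxicity, read by MTT assay, with a stated time of 48 h (on this read-out higher numbers stand for weaker inhibition and lower numbers for stronger inhibition), compound 1 `CC(C)=CCC/C(C)=C/CC/C(C)=C/CC[C@@H]1[C@@]2(C)CC/C(=N\OCc3cn(-c4ccc(F)c(F)c4F)nn3)C(C)(C)[C@@H]2CC[C@@]1(C)O` gives 32300 nM. Compound 2 `COc1cccc(-n2cc(COc3ccc(/C=C4\C[C@]5(C)[C@@H](CC/C=C(\C)CC/C=C(\C)CCC=C(C)C)[C@](C)(O)CC[C@H]5C(C)(C)C4=O)cc3)nn2)c1` gives 16600 nM in this assay. These two numbers lie within the usual scatter of each other, so neither compound can be said to inhibit the cells more strongly than the other. Among the compounds with values here, no pair of measured compounds differs in a single place, so there is no direct guide to how one small change moves the read-out here. Compound 3 `CC(C)=CCC/C(C)=C/CC/C(C)=C/CC[C@@H]1[C@@]2(C)C/C(=C\c3ccc(OCc4cn(-c5cccc([N+](=O)[O-])c5)nn4)cc3)C(=O)C(C)(C)[C@@H]2CC[C@@]1(C)O` differs from compound 2 by nitro in place of methoxy on an aromatic carbon. Within the data shown here, with no measured step to lean on, the change from compound 2 to compound 3 is expected to stay within the scatter, giving an estimated step of a 1.1-fold lower number from compound 2 to compound 3 (0.04 log units; within the scatter). On that basis compound 3 is expected to give about 15000 nM in this assay, within a range from 5000 nM to 45000 nM.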

Compound 3, half-maximal inhibitory concentration: 79400 nM
For compound 3 the middle estimate is 5.3-fold (0.72 log units) below the measured one; measured number outside the range, above it.
By their numbers in this assay, from the lowest: compounds 2 and 1 (each within the scatter of the next); then compound 3.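

In this assay, within the data shown here, the swap of 3-methoxyphenyl to 3-nitrophenyl gives a 4.8-fold higher number from compound 2 to compound 3 (0.68 log units; beyond the scatter) and so provides the first reading of a change in a single place on this core. The step is modest, but it shows that the group on this aromatic carbon, meta to a large group, can move the read-out: between these two compounds, methoxy goes with the stronger inhibition of the cells and nitro with the weaker. What lies behind this shift cannot be told from any information available here.

Among these compounds, with only two groups compared at this position, it remains open where a chlorine, an amine or a carboxylic acid would fall relative to compound 2 and compound 3. As far as these compounds go, it is also open whether the same swap would give a similar step on another carbon of this ring.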